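The source may report more compounds than this note shows. Statements on the series, on what has been measured and on what is new or still open speak of the compounds shown alone.

Working notes on the series. Compound 1 `COCc1cc(CCCOc2c(C)cc(-c3noc(C(F)(F)F)n3)cc2C)on1` and compound 2 `CCOCc1cc(CCCOc2c(C)cc(-c3noc(C(F)(F)F)n3)cc2C)on1` share one core and differ only by methyl in place of hydrogen on a saturated chain carbon bound to an oxygen on a saturated carbon. In an in vitro ADME assay on microsomes from liver (Simiiformes) (on this read-out higher numbers stand for a longer-lived compound and lower numbers for a shorter-lived compound), compound 1 gives 1.58 h. Compound 2 returns only a limit of the assay in this assay, > 2.5 h. The step reads an at least 1.5-fold higher number from compound 1 to compound 2 (0.19 log units; that floor lies within the scatter), its floor set by the limit of > 2.5 h in this assay, at which 1 of the 3 values shown sits. Compound 3 `Cc1cc(CCCOc2c(C)cc(-c3noc(C(F)F)n3)cc2C)on1` carries another core; the difference between the two cores is not broken down here. In this assay compound 3 gives 1.42 h, which sits close to the number for compound 1, within the usual scatter. Compound 4 `Cc1cc(CCCOc2c(C)cc(-c3noc(C(C)(F)F)n3)cc2C)on1` is not yet measured and differs from compound 3 by methyl in place of hydrogen on a saturated chain carbon bound to an aromatic carbon and two fluorine atoms. This is the same kind of change as that between compound 1 and compound 2, but the place is not the same: there the carbon was bound to an oxygen on a saturated carbon, here it is bound to an aromatic carbon and two fluorine atoms. Resting on an at least 1.5-fold higher number from compound 1 to compound 2 (0.19 log units; that floor lies within the scatter), a step of a 1.3-fold higher number from compound 3 to compound 4 (0.10 log units; within the scatter) is expected. Compound 4 is estimated at 1.8 h, with a likely range from 1 h to 3 h.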

Compound 4, half-life: 1.1 h
Compound 4: middle estimate off by 1.6-fold (0.21 log units), on the high side, and the stated range covers the measured number.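

In this assay, the new step reads a 1.3-fold lower number from compound 3 to compound 4 (0.11 log units; within the scatter), so on the core of compound 3 this change, made on a saturated chain carbon bound to an aromatic carbon and two fluorine atoms, stays within the usual scatter. Set beside the earlier step, this does not show that the change carries over from one core to the other, nor does it show that the outcome depends on the core: the same change on two cores in this assay, an at least 1.5-fold higher number (0.19 log units; that floor lies within the scatter) from compound 1 to compound 2 and a 1.3-fold lower number (0.11 log units; within the scatter) from compound 3 to compound 4; the limit leaves it open whether they differ Compound 2 stands at a limit of the assay and not at a number, so the earlier step has only a floor, and the two steps also sit at different places: the limit of > 2.5 h in this assay, at which 1 of the 4 values shown sits.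

The compounds shown leave open how far the step from compound 1 to compound 2 reaches past its floor, and whether one place would behave alike on both cores. Also open, from the compounds shown here alone, is what a longer chain, an amine or a carboxylic acid would do at the carbon changed in compound 4.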